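Swapping iodo for methyl on a thiophene carboxamide

This account rests on a few compounds, and the source may have more. Where it says the series, first, only, none or still open, it means among the compounds named here.

Compound 2 `NC(=O)c1c(NC(=O)c2ccccc2I)sc2c1CCN(C(=S)Nc1ccccc1Br)C2` gives 22400 nM in a functional assay on MKN-74 cells (Homo sapiens) for antiproliferative activity, with a stated time of 24 h (on this read-out higher numbers stand for weaker inhibition and lower numbers for stronger inhibition), the higher of the two numbers measured, while compound 1 `Cc1ccccc1C(=O)Nc1sc2c(c1C(N)=O)CCN(C(=S)Nc1ccccc1Cl)C2` gives 11000 nM in this assay, a gap beyond the scatter. Compound 3 `Cc1ccccc1C(=O)Nc1sc2c(c1C(N)=O)CCN(C(=S)Nc1ccccc1Br)C2` differs from compound 2 by methyl in place of iodo on an aromatic carbon. Among the measured compounds shown here, with no measured pair showing this change, a modest step toward a lower number is expected, of a size a 1.6-fold lower number from compound 2 to compound 3 (0.20 log units; within the scatter), because compound 1, which also carries the methyl, stands at 11000 nM. Compound 3 is therefore estimated at 14000 nM in this assay, within a range from 6000 nM to 35000 nM.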

Compound 3, half-maximal inhibitory concentration: > 50000 nM
Compound 3 was reported as a limit; the forecaster's own chance of this, stated with the estimate: 10%; at least 3.5-fold (0.55 log units) between middle value and limit.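

Compound 3 is reported in this assay only as a limit of the assay: the limit of > 50000 nM in this assay, at which 1 of the 3 values shown sits. Read against that limit, methyl is no neutral replacement for iodo at this place, ortho to a large group, giving an at least 2.2-fold higher number from compound 2 to compound 3 (0.34 log units; beyond the scatter) on the 2-iodophenyl to 2-methylphenyl change. Bromo in place of chloro on an aromatic carbon, with the 2-methylphenyl kept, gives an at least 4.5-fold higher number from compound 1 to compound 3 (0.65 log units; beyond the scatter) and so also matters in this series.

As far as these compounds go, the true size of both steps remains open. So does how a fluoro, methoxy or carboxylic acid group would read at this place.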